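The source may report more compounds than this note shows. Statements on the series, on what has been measured and on what is new or still open speak of the compounds shown alone.

Compound 1 `CNC(=O)c1cc(Oc2cccc(NC(=S)Nc3ccc(Cl)cc3)c2)ccn1` belongs to a small set tested in a functional assay on MDA-MB-231 cells (Homo sapiens) for cytotoxicity, read by MTT assay, with a stated time of 48 h; on this read-out higher numbers stand for weaker inhibition and lower numbers for stronger inhibition. In this assay compound 1 gives > 100000 nM, a limit of the assay rather than a number. Compound 2 `O=C(NCc1ccccc1)c1cc(Oc2cccc(NC(=S)Nc3ccc(Cl)cc3)c2)ccn1` differs from compound 1 by a phenyl in place of hydrogen on a saturated chain carbon bound to an amide-type nitrogen. In this assay compound 2 gives > 100000 nM, again a limit. The step that the two limits leave unreadable from compound 1 to compound 2 is unreadable, since both values sit at the same limit (the limit of > 100000 nM in this assay, at which 2 of the 2 values shown sit). Compound 3 `CNC(=O)c1cc(Oc2cccc(NC(=S)Nc3ccc(OC(F)(F)F)cc3)c2)ccn1` has not yet been measured. It differs from compound 1 as follows: trifluoromethoxy in place of chloro on an aromatic carbon. No measured step touches this position, and the only step shown gives no size. Nothing in the numbers points to a change beyond the scatter, so the step of a number no higher from compound 1 to compound 3 (the limit leaves the size open) is expected to be small. Compound 3 is estimated at 100000 nM in this assay, with a range from 30000 nM to 300000 nM.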

Compound 3, half-maximal inhibitory concentration: > 100000 nM
Compound 3 gave a limit, no number; the forecaster's own chance of this, stated with the estimate: 80%; the middle value sits exactly at the limit.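

In this assay, among these compounds, compound 3 gives > 100000 nM as a limit of the assay and not a number, so no step between compound 1 and compound 3 can be read, as both sit at the same limit: the limit of > 100000 nM in this assay, at which 3 of the 3 values shown sit.

The compounds shown leave open whether trifluoromethoxy in place of chloro changes the cytotoxicity at all.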